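Methyl to Chloro: Estimating Compound 3 from Compound 2

The source may report more compounds than this note shows. Statements on the series, on what has been measured and on what is new or still open speak of the compounds shown alone.

Compound 1, `Cc1cc(=O)oc2cc(OCc3nc(N)nc(Nc4ccc(C(C)C)cc4)n3)ccc12`, gives 460 nM in an assay on COS-7 cells for agonist activity at Free fatty acid receptor 1 (Homo sapiens), read by scintillation counting and inositol phosphate accumulation, with a stated time of 90 min; a lower number here means that less compound is needed, a higher number that more compound is needed for the effect.
Compound 2, `Cc1ccc(Nc2nc(N)nc(COc3ccc4c(C)cc(=O)oc4c3)n2)cc1Cl`, gives 140 nM in this assay.

Among the measured compounds shown here, of these two measured compounds, compound 2 stands at the lower number; its only neighbour is compound 1, and the step of a 3.3-fold lower number from compound 1 to compound 2 (0.52 log units; beyond the scatter) lies beyond the scatter. Compound 3, `Cc1cc(=O)oc2cc(OCc3nc(N)nc(Nc4ccc(Cl)c(Cl)c4)n3)ccc12`, has not yet been measured in this assay. It differs from compound 2 in one place: chloro in place of methyl on an aromatic carbon. For the measured compounds named here, the single measured step, a 3.3-fold lower number from compound 1 to compound 2 (0.52 log units; beyond the scatter), replaced one substituted ring with another of a different pattern, so it does not speak directly to a lone exchange of methyl for chloro, and no other pair here shows that exchange. Going by the values given here, with no comparable step to lean on, compound 3 is expected to land near the value of its parent, with a step of a 1.2-fold lower number from compound 2 to compound 3 (0.07 log units; within the scatter) that should stay within the scatter. On that basis compound 3 is estimated at 120 nM in this assay, with a plausible range from 50 nM to 350 nM.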

Compound 3, half-maximal effective concentration: 780 nM
Compound 3: the middle estimate sits 6.5-fold (0.81 log units) below what was measured; the measured number lies above the stated range.
By their numbers in this assay, from the lowest: compound 2; then compounds 1 and 3 (each within the scatter of the next).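

In this assay, among the compounds shown here, the methyl group of the 3-chloro-4-methylphenyl ring in compound 2 proves not to be interchangeable with chloro: on this aromatic carbon, ortho to a chloro group and para to a large group, the exchange gives a clear step (a 5.6-fold higher number from compound 2 to compound 3 (0.75 log units; beyond the scatter)) although only one heavy atom changes and the counts of rings, hydrogen-bond donors, hydrogen-bond acceptors and net charge stay the same. The 3,4-dichlorophenyl group also loses the separation that compound 2 showed from compound 1, since the pair lies close together (a 1.7-fold higher number from compound 1 to compound 3 (0.23 log units; within the scatter)), and of the three rings only the 3-chloro-4-methylphenyl ring stands apart from the other two. Nothing at hand accounts for the step from methyl to chloro.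

On these data alone, whether methyl itself matters at this carbon, or whether an ethyl, methoxy or trifluoromethyl group would serve as well, remains open. Also open, as far as these compounds go, is how much the remaining chloro group contributes, a question that a plain 4-methylphenyl ring on the same core would address.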